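This account rests on a few compounds, and the source may have more. Where it says the series, first, only, none or still open, it means among the compounds named here.

Compound 1 `CC(=O)N[C@@H]1CCC[C@H](C(=O)Nc2cc(-c3cnn4ccccc34)c(Cl)cn2)C1` is the most lipophilic of the three measured compounds in a physicochemical assay for lipophilicity, using the shake flask method, measured as octanol-water partition, at pH 7.4 (a higher number here means a more lipophilic compound, a lower number a more polar compound), where compound 1 gives 3.6. Compound 2 `CC(=O)N[C@@H]1CCC[C@H](C(=O)Nc2cc(-c3cnc(C)n3C)c(Cl)cn2)C1` gives 2.2 and compound 3 `CC(=O)N[C@@H]1CCC[C@H](C(=O)Nc2cc(-c3cnn4c3OCCC4)c(Cl)cn2)C1` gives 2.6. Both steps away from compound 1 changed the group on the same aromatic carbon: a number 1.40 log units lower from compound 1 to compound 2 (beyond the scatter), and a number 1.00 log units lower from compound 1 to compound 3 (beyond the scatter). Compound 4 `CC(=O)N[C@@H]1CCC[C@H](C(=O)Nc2cc(-c3cnc4n3CC(C)(C)C4)c(Cl)cn2)C1` alters that position again: a group of 10 heavy atoms (8 carbon, 2 nitrogen; one five-membered non-aromatic ring with 1 hetero atom, one five-membered aromatic ring with 2 hetero atoms) in place of a group of 9 heavy atoms (7 carbon, 2 nitrogen; one five-membered aromatic ring with 2 hetero atoms, one six-membered aromatic ring with 1 hetero atom), on an aromatic carbon. The two earlier steps at this carbon both lowered the number, one by a large margin and one by a modest one, so a drop beyond the scatter is expected here too, though with the larger entering group a smaller one than for compound 2. Compound 4 is therefore estimated at 3, between 2.5 and 3.5, an expected step of a number 0.60 log units lower from compound 1 to compound 4 (beyond the scatter).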

Compound 4, distribution coefficient: 3.6
For compound 4 the middle estimate is 0.60 log units below the measured one; measured number outside the range, above it.
By their numbers in this assay, from the lowest: compound 2; then compound 3; then compounds 1 and 4 (each within the scatter of the next).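

In this assay the result shows that a change on this aromatic carbon need not lower the number: no change at the digits printed from compound 1 to compound 4 (within the scatter) even though the six-membered aromatic ring of the leaving group is gone. The entering group also stands well apart from the other two replacements, with a number 1.00 log units higher from compound 3 to compound 4 (beyond the scatter) and a number 1.40 log units higher from compound 2 to compound 4 (beyond the scatter) in this series. A second ring that is aromatic is thus not needed to reach the number of compound 1. As far as these compounds go, whether a hydroxyl or an amine on the non-aromatic ring would bring the number down stays open. Nothing shown here explains these differences.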